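The source may report more compounds than this note shows. Statements on the series, on what has been measured and on what is new or still open speak of the compounds shown alone.

Compound 1 `CCCCCCCC/C=C/CCCCCCCC(=O)Nc1ccccc1C(C)C`: in an assay on microsomes from intestine for inhibition of acyl-CoA:cholesterol acyltransferase (Oryctolagus cuniculus) (on this read-out higher numbers stand for weaker inhibition and lower numbers for stronger inhibition), compound 1 gives 600 nM.
Compound 2 `CCCCCCCC/C=C/CCCCCCCC(=O)Nc1cccc(C(=O)OC)c1C`: compound 2 gives > 5000 nM, which is a limit of this assay and not a number.
Compound 3 `CCCCCCCC/C=C/CCCCCCCC(=O)Nc1cc(C(=O)OC)ccc1OC`: compound 3 gives 430 nM.

Among the compounds with values here, compound 1 and compound 3 are the only two with a number, and these two numbers lie within the scatter of each other, so neither can be set above or below the other. Compound 2 contributes only a limit in this assay, (the limit of > 5000 nM in this assay, at which 1 of the 3 values shown sits).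

Compound 4 `CCCCCCCC/C=C/CCCCCCCC(=O)Nc1c(C)cccc1C(C)C` has not yet been measured. It differs from compound 1 in one place: methyl in place of hydrogen on an aromatic carbon. Within the data shown here, no step between two measured compounds matches this change, so there is nothing in the data to set its size directly. The shift is expected to be small, toward stronger inhibition if anything, and may well stay within the scatter. For compound 4 the expected value in this assay is 300 nM, with a range from 100 nM to 1000 nM. The step this estimate implies is a 2.0-fold lower number from compound 1 to compound 4 (0.30 log units; within the scatter), and it is an expectation only.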

Compound 4, half-maximal inhibitory concentration: 23 nM
For compound 4 the middle estimate is 13-fold (1.12 log units) above the measured one; measured number outside the range, below it.
By their numbers in this assay, from the lowest: compound 4; then compounds 3 and 1 (each within the scatter of the next). At a limit, above all of these: compound 2.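

The step in this assay is a 26-fold lower number from compound 1 to compound 4 (1.42 log units; beyond the scatter) for a single methyl in place of hydrogen on an aromatic carbon, ortho to a large group. Within the data shown here, this shows that the position is far from indifferent to substitution: one added heavy atom is enough for a large step toward stronger inhibition, something the earlier compounds could not show, as no two of them differed in only one place. The compounds shown offer no reason for the size of this step.

Going by these compounds, whether a larger or different group at this place, such as ethyl, methoxy or an amine, would go further or lose the gain remains open. So does whether the same methyl would give a similar step without the isopropyl group, as this change is seen in one pair alone.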